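The source may report more compounds than this note shows. Statements on the series, on what has been measured and on what is new or still open speak of the compounds shown alone.

Measured so far:
compound 1, `CN1CCC[C@@H]1Cn1nc(Cc2ccc(F)c(F)c2)c2ccccc2c1=O` — in an assay for binding affinity to Alpha-1B adrenergic receptor (Homo sapiens) (a lower number here means a stronger inhibitor, a higher number a weaker inhibitor), compound 1 gives 316 nM.
compound 2, `CN1CCC[C@@H]1Cn1nc(Cc2ccc(C(C)(C)C)cc2)c2ccccc2c1=O` — in this assay compound 2 gives only > 1990 nM, a limit of the assay and not a number.

Compound 2 thus stands at the upper edge of what the assay reports, as the limit of > 1990 nM in this assay, at which 1 of the 2 values shown sits, records; no binding number is known for it. Compound 3, `CN1CCC[C@@H]1Cn1nc(Cc2ccc(F)cc2)c2ccccc2c1=O`, differs from compound 2 by fluoro in place of tert-butyl on an aromatic carbon. Compound 1, which also carries fluoro on that ring, gives 316 nM in this assay. The step from compound 2 to compound 3 is expected to be a gain in binding beyond the scatter, an at least 4.4-fold lower number from compound 2 to compound 3 (0.64 log units; beyond the scatter). Compound 3 is estimated at 450 nM, within 150 nM to 1300 nM.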

Compound 3, inhibition constant: 79.4 nM
Compound 3: the middle estimate sits 5.7-fold (0.75 log units) above what was measured; the whole stated range lies above it.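

At the aromatic carbon para to a large group, fluoro in place of tert-butyl gives an at least 25-fold lower number from compound 2 to compound 3 (1.39 log units; beyond the scatter) in this assay. Compound 2 stands at a limit of the assay and not at a number, so this step is a bound only: the limit of > 1990 nM in this assay, at which 1 of the 3 values shown sits. Hydrogen in place of fluoro on the ring of compound 1 gives a 4.0-fold lower number from compound 1 to compound 3 (0.60 log units; beyond the scatter), so the single fluoro of compound 3 binds better than the pair on compound 1.

Open, going by these compounds, is whether hydrogen, methoxy or a carboxylic acid in place of the remaining fluoro would hold binding near that of compound 3.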